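The compounds below may be only part of what the source reports. "The series", "measured", "known", "first", "only" and "open" are said of these compounds alone.

Measured in a physicochemical assay for pharmacokinetics, at pH 6; on this read-out higher numbers stand for a longer-lived compound and lower numbers for a shorter-lived compound:
- compound 1 `O=C(Sc1cccnc1C(=O)O)c1cccc(Cl)c1`: 4.7 h
- compound 2 `O=C(Sc1cccnc1C(=O)O)c1cccc(C(F)(F)F)c1`: 3.9 h
- compound 3 `O=C(Sc1cccnc1C(=O)O)c1ccc(C(F)(F)F)cc1`: 3 h

The three values lie within the scatter of one another, so compound 3, at 3 h, holds no distinct rank in this small set.

The next step leads to compound 4 `O=C(Sc1cccnc1C(=O)O)c1ccc([N+](=O)[O-])cc1`, which keeps the shared core of compound 3 and changes one group: nitro in place of trifluoromethyl on an aromatic carbon. In words, nitro takes the place of trifluoromethyl on an aromatic carbon, para to a large group.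

Among the measured compounds shown here, only one measured step bears on this change, and only loosely. Exchanging one group for another on an aromatic carbon gave a 1.2-fold lower number from compound 1 to compound 2 (0.08 log units; within the scatter). For the measured compounds named here, that step is a different exchange, and no measured compound carries nitro, so the data give no direct reading for this group. Going by the values given here, the series so far shows no exchange that moves the value beyond the scatter, and the one measured step is small. A shift beyond the scatter is therefore not expected, and the direction remains uncertain.

The expected change is a 1.2-fold lower number from compound 3 to compound 4 (0.08 log units; within the scatter). In this assay, the estimate for compound 4 is 2.5 h, with an expected range from 1.4 h to 4.2 h.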

Compound 4, half-life: 1.4 h
Compound 4: the middle estimate sits 1.8-fold (0.25 log units) above what was measured; low and high end bracket the measured number.
By their numbers in this assay, from the lowest: compound 4; then compounds 3, 2 and 1 (each within the scatter of the next).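

In this assay, nitro in place of trifluoromethyl on an aromatic carbon, para to a large group, gives a 2.1-fold lower number from compound 3 to compound 4 (0.33 log units; beyond the scatter), and this modest step is the first in the series shown to pass beyond the scatter. Among the compounds shown here, the earlier step, a different exchange on an aromatic carbon, gave a 1.2-fold lower number from compound 1 to compound 2 (0.08 log units; within the scatter) and stayed within the scatter, so the earlier compounds showed no sensitivity of the half-life to a single group exchange. Compound 4 now shows that such an exchange on this ring can move the read-out, although no available measurement accounts for the lower number.

From the compounds shown here alone, it remains open whether this step is specific to nitro or would also appear with other groups at the same place, such as a nitrile, an amine or a carboxylic acid. Going by these compounds, it also remains open whether nitro would give a step of similar size at the place that carries chloro in compound 1 and trifluoromethyl in compound 2, which would show how far the result depends on position rather than on the group alone.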